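A wider change to the side chain of compound 1

This account rests on a few compounds, and the source may have more. Where it says the series, first, only, none or still open, it means among the compounds named here.

Compound 1 `COC(=O)/C=C/c1ccncc1-c1ccc2ccccc2c1` gives the highest number of the three compounds in an assay on a protein complex for inhibition of CDK8/Cyclin C (Homo sapiens), with a stated time of 1 h, tested at 10 uM (a lower number here means less inhibition, a higher number more inhibition at the concentration tested (going by the name of the read-out)), at 102%. Compound 2 `O=C(O)[C@@H]1CCCN1C(=O)/C=C/c1ccncc1-c1ccc2ccccc2c1` gives 67% and compound 3 `O=C(O)CCNC(=O)/C=C/c1ccncc1-c1ccc2ccccc2c1` gives 91%. Each change made at the carbonyl carbon of compound 1 lowered inhibition: a number 35 percentage points lower from compound 1 to compound 2 (beyond the scatter) and a number 11 percentage points lower from compound 1 to compound 3 (beyond the scatter). Compound 4 `NNC(=O)COc1ccncc1-c1ccc2ccccc2c1` differs from compound 1 more widely: (aminocarbamoyl)methoxy in place of 2-(methoxycarbonyl)ethenyl on an aromatic carbon. The measured steps touched only the end of the chain, yet each cost inhibition, so this larger change is expected to cost at least as much, with broad uncertainty. The estimated step is a number 47 percentage points lower from compound 1 to compound 4 (beyond the scatter). Compound 4 is thus expected to give 55%, with a range from 20% to 90%.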

Compound 4, a percentage reported as inhibition, at one concentration (the size of the read-out at that concentration, not a potency): 19%
Compound 4: middle estimate off by 36 percentage points, on the high side; measured number below the stated range.
By their numbers in this assay, from the lowest: compound 4; then compound 2; then compound 3; then compound 1.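

In this assay, replacing the whole 2-(methoxycarbonyl)ethenyl group on this aromatic carbon with (aminocarbamoyl)methoxy gives a number 83 percentage points lower from compound 1 to compound 4 (beyond the scatter), a far bigger loss than either change at the carbonyl carbon. The two groups match in heavy atoms, so the loss came without any change in that count. Nothing measured here explains it. The chain and its end changed together, leaving open which of them carries the loss. A carboxylic acid on the methoxy link, or the aminocarbamoyl end on the ethenyl chain, would separate the two.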